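A few compounds are considered here, and "the series" means these few. Any claim that something is new, unique, unknown or untested is made for them only; others in the source may bear on it.

Measured compounds:
compound 1, `Cn1nc2c(=O)n(CC3(O)CCN(Cc4ccc(-c5ccncc5)cc4Cl)CC3)cnc2c1-c1ccc(CN)cc1`: 257 nM
compound 2, `CC(=O)NCc1ccc(-c2c3ncn(CC4(O)CCN(Cc5ccc(-c6ccco6)cc5Cl)CC4)c(=O)c3nn2C)cc1`: 46.1 nM

Both values come from an assay on isolated protein for inhibition of ubiquitin carboxyl-terminal hydrolase 7 (Homo sapiens), with stated times of 30 min and 2 h; on this read-out higher numbers stand for weaker inhibition and lower numbers for stronger inhibition. Compound 1 gives 257 nM, the higher of the two numbers. Compound 2 gives 46.1 nM, a lower number whose distance from compound 1 lies beyond the usual scatter of this assay. For the measured compounds named here, compound 2 differs from compound 1 in more than one place, so the gap cannot be tied to any single change; the two values show only that compound 2 inhibits more strongly than compound 1.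

Compound 3, `Cn1nc2c(=O)n(CC3(O)CCN(Cc4ccc(-c5cncs5)cc4Cl)CC3)cnc2c1-c1ccc(CN)cc1`, has not yet been measured. It differs from compound 1 in one place: 1,3-thiazol-5-yl in place of pyridin-4-yl on an aromatic carbon. One small aromatic ring replaces another on the same aromatic carbon, and the chloro group and the large group on that ring stay as they are. Going by the values given here, no pair of measured compounds differs in this way alone, so nothing measured here shows how such an exchange moves the result. The step of a 1.0-fold higher number from compound 1 to compound 3 (0.01 log units; within the scatter) is expected to be small, none beyond the scatter. Compound 3 is expected to give about 260 nM in this assay, with a likely range from 100 nM to 650 nM.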

Compound 3, half-maximal inhibitory concentration: 117 nM
Compound 3: the middle estimate sits 2.2-fold (0.35 log units) above what was measured; the range from low to high includes it.
By their numbers in this assay, from the lowest: compound 2; then compound 3; then compound 1.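

In this assay, for the compounds shown here, 1,3-thiazol-5-yl in place of pyridin-4-yl gives a 2.2-fold lower number from compound 1 to compound 3 (0.34 log units; beyond the scatter), the first single change here whose effect can be read. It shows that this aromatic carbon, meta to a chloro group and para to a large group, is not indifferent to which small aromatic ring it carries: the exchange moves the number modestly toward stronger inhibition, with everything else in the molecule held the same. This one exchange alters several things at once, since a five-membered aromatic ring with 2 hetero atoms, one of them sulfur, replaces a six-membered aromatic ring with 1 hetero atom, and nothing available explains why the number moved or which of these differences matters.

As far as these compounds go, it remains open whether a plain phenyl ring, a pyridin-3-yl ring or a non-aromatic ring such as morpholin-4-yl at this carbon would give a number closer to that of compound 3 or to that of compound 1. From the compounds shown here alone, it also remains open whether the same exchange would move the number by a similar amount with an acetamide in place of the aminomethyl group at the other end of the molecule.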